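Swapping fluoro for methyl on a thiourea amide

The source may report more compounds than this note shows. Statements on the series, on what has been measured and on what is new or still open speak of the compounds shown alone.

Measured compounds:
- compound 1, `Cc1ccc(NC(=S)NC(=O)c2cn(-c3ccccc3)nc2-c2ccc(F)cc2)cc1`: 2080 nM
- compound 2, `O=C(NC(=S)Nc1ccc(F)cc1)c1cn(-c2ccccc2)nc1-c1ccccc1`: 3500 nM

Of the compounds shown here, two have been measured in a functional assay on A549 cells (Homo sapiens) for inhibition, read by CCK-8 assay, with a stated time of 48 h; on this read-out higher numbers stand for weaker inhibition and lower numbers for stronger inhibition. Compound 1 gives 2080 nM there, and compound 2 gives 3500 nM. These two numbers lie within the usual scatter of each other, so neither compound stands apart from the other on this read-out.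

The next compound to consider is compound 3, `Cc1ccc(NC(=S)NC(=O)c2cn(-c3ccccc3)nc2-c2ccc(C)cc2)cc1`. It differs from compound 1 in one place only: methyl in place of fluoro on an aromatic carbon. For the measured compounds named here, no measured pair in this set shows the effect of that particular change, so there is nothing in the data to anchor a direction. With a single heavy atom exchanged for a single heavy atom, and no change in donors, acceptors or charge, the reasonable expectation is a step that stays inside the scatter, neither clearly stronger nor clearly weaker than compound 1.

On that basis compound 3 is expected to give about 2200 nM in this assay, with a likely range of 900 nM to 5500 nM, and the step from compound 1 to compound 3 is estimated as a 1.1-fold higher number from compound 1 to compound 3 (0.02 log units; within the scatter).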

Compound 3, half-maximal inhibitory concentration: 2830 nM
Estimate against measurement, compound 3: 1.3-fold (0.11 log units) below; the range from low to high includes it.
By their numbers in this assay, from the lowest: compounds 1, 3 and 2 (each within the scatter of the next).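

For the compounds shown here, compound 3 gives the first direct reading of this exchange at this position: in this assay the move from 4-fluorophenyl to 4-methylphenyl amounts to a 1.4-fold higher number from compound 1 to compound 3 (0.13 log units; within the scatter) and so cannot be told apart from repeat-measurement noise. For this one pair on the shared core, then, fluoro and methyl on an aromatic carbon, para to a large group, are interchangeable on this read-out, and neither group can be ranked over the other. No other measurement bears on this result, so nothing here can explain why the two groups read alike.

Still open, from the compounds shown here alone, is whether a group of a different kind at this same place, such as an amine, a carboxylic acid or a longer chain, would carry the number beyond the usual scatter in either direction. A single pair also cannot show whether fluoro and methyl would stay interchangeable if the rest of the molecule were different, so this result holds only for compound 1 and compound 3.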